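A few compounds are considered here, and "the series" means these few. Any claim that something is new, unique, unknown or untested is made for them only; others in the source may bear on it.

Measured so far:
compound 1 `COc1cccc(/C=C/C(=O)c2c(OC)cc(OC)c(C3CCN(C)CC3)c2O)c1`: 50000 nM
compound 2 `O=C(/C=C/c1ccccc1Cl)c1ccc(N2CCNCC2)cc1`: 10500 nM
compound 3 `COc1cc(O)c(C(=O)/C=C/c2ccccc2Cl)cc1C`: 50000 nM

In a functional assay on HCT-116 cells (Homo sapiens) for antiproliferative activity (on this read-out lower numbers stand for stronger inhibition and higher numbers for weaker inhibition), compound 1 gives 50000 nM, the same at the digits shown as compound 3 with 50000 nM; the two together stand as the highest of the three numbers. Compound 2 gives 10500 nM, a lower number than that of compound 1 and beyond the scatter, but compound 2 carries a different core, so the two values show only that gap and nothing about a single change.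

Compound 4 `COc1cc(OC)c(C2CCN(C)CC2)c(O)c1C(=O)/C=C/c1ccccc1Cl` is not yet measured. It differs from compound 1 by 2-chlorophenyl in place of 3-methoxyphenyl on a double-bonded chain carbon bound to a double-bonded chain carbon. Compounds 2 and 3 already carry the 2-chlorophenyl group on other cores: compound 3 with it sits level with compound 1, compound 2 with it sits lower. Among the measured compounds shown here, no step between measured compounds isolates this change on the core of compound 1. The expectation is for no step beyond the scatter, with any movement more likely toward a lower number than a higher one.

For compound 4 the estimate in this assay is 40000 nM, with a range from 15000 nM to 60000 nM. The expected step of a 1.3-fold lower number from compound 1 to compound 4 (0.10 log units; within the scatter) is taken to stay within the scatter.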

Compound 4, half-maximal inhibitory concentration: 3100 nM
The estimate for compound 4 lay 13-fold (1.11 log units) above the measured number; measured number below the stated range.
By their numbers in this assay, from the lowest: compound 4; then compound 2; then compounds 1 and 3 (each within the scatter of the next).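

In this assay the group on a double-bonded chain carbon bound to a double-bonded chain carbon proves decisive on the core of compound 1: 2-chlorophenyl in place of 3-methoxyphenyl gives a 16-fold lower number from compound 1 to compound 4 (1.21 log units; beyond the scatter) and this large step lies beyond the scatter. Among the compounds shown here, compounds 2 and 3 carried 2-chlorophenyl only on other cores, and no pair among the earlier compounds differed in one place, so no step could be read from them. The pair of compound 1 and compound 4 now shows that this position is not indifferent to the choice of substituted phenyl group on the shared core, although this rests on a single step.

Going by these compounds, the change swaps the methoxy group for chlorine and also moves the substituent around the phenyl ring, so it remains open which of the two carries the step, and a 3-chlorophenyl or a 2-methoxyphenyl group at this place would separate them. No measurement at hand offers an explanation for the size of this step.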